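Replacing the amine in compound 3 with a sulfur group

This account rests on a few compounds, and the source may have more. Where it says the series, first, only, none or still open, it means among the compounds named here.

Compound 1 `CCN(CC)C/C1=C/C[C@](C)(CCC=C(C)C)/C=C/[C@@H](OC(=O)C=C(C)C)[C@](C)(O)/C=C/C1=O`: 140 nM
Compound 2 `CC(C)=CCC[C@]1(C)/C=C/[C@@H](OC(=O)C=C(C)C)[C@](C)(O)/C=C/C(=O)/C(CN(C(C)C)C(C)C)=C\C1`: 740 nM
Compound 3 `CC(C)=CCC[C@]1(C)/C=C/[C@@H](OC(=O)C=C(C)C)[C@](C)(O)/C=C/C(=O)/C(CN2CCN(C)CC2)=C\C1`: 840 nM

All three values come from a functional assay on HL-60 cells (Homo sapiens) for antiproliferative activity, read by MTT assay, with a stated time of 48 h; a higher number here means a weaker inhibitor, a lower number a stronger inhibitor. Compound 3 has the highest number of the three at 840 nM, although the step of a 1.1-fold higher number from compound 2 to compound 3 (0.06 log units; within the scatter) does not separate it from compound 2. The step of a 6.0-fold higher number from compound 1 to compound 3 (0.78 log units; beyond the scatter) does set it apart from compound 1.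

Compound 4 `CSC(=S)OC/C1=C/C[C@](C)(CCC=C(C)C)/C=C/[C@@H](OC(=O)C=C(C)C)[C@](C)(O)/C=C/C1=O` differs from compound 3 in one place: a group of 5 heavy atoms (2 carbon, 1 oxygen, 2 sulfur; no ring) in place of a group of 7 heavy atoms (5 carbon, 2 nitrogen; one six-membered non-aromatic ring with 2 hetero atoms), on a saturated chain carbon bound to a double-bonded ring carbon. The nearest evidence comes from the amino swaps at that place, namely a 5.3-fold higher number from compound 1 to compound 2 (0.72 log units; beyond the scatter) and a 6.0-fold higher number from compound 1 to compound 3 (0.78 log units; beyond the scatter), both modest, and a 1.1-fold higher number from compound 2 to compound 3 (0.06 log units; within the scatter). Within the data shown here, all three measured groups contain nitrogen, and the group in compound 4 contains none, so the data offer no direct precedent. Given steps of that modest size, no step beyond the scatter is expected in this assay, and the direction remains open.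

For compound 4 the expected value is 500 nM, with an estimated range from 130 nM to 1800 nM. This estimate means an expected 1.7-fold lower number from compound 3 to compound 4 (0.23 log units; within the scatter).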

Compound 4, half-maximal inhibitory concentration: 180 nM
Compound 4: middle estimate off by 2.8-fold (0.44 log units), on the high side; the measured number falls inside the stated range.
By their numbers in this assay, from the lowest: compounds 1 and 4 (each within the scatter of the next); then compounds 2 and 3 (each within the scatter of the next).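

In this assay the place on a saturated chain carbon bound to a double-bonded ring carbon turns out to tolerate a group without nitrogen, as the sulfur-bearing group gives a 4.7-fold lower number from compound 3 to compound 4 (0.67 log units; beyond the scatter) and a 4.1-fold lower number from compound 2 to compound 4 (0.61 log units; beyond the scatter) in the other comparison. Set against diethylamino, the same group gives a 1.3-fold higher number from compound 1 to compound 4 (0.11 log units; within the scatter) and so stays within the scatter, which shows that an amine is not needed to reach the low end of this series. Across these four compounds, the two groups of 5 heavy atoms give lower numbers than the two groups of 7 heavy atoms, and no compound goes against this, but no measurement at hand explains the result.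

What the compounds shown leave open is whether a smaller amine such as dimethylamino, or an acetate ester carrying no sulfur, would sit with compound 1 and compound 4 or with compound 2 and compound 3.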